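Aryl Amide Variation in a Dopamine Receptor Agonist Series

The compounds below may be only part of what the source reports. "The series", "measured", "known", "first", "only" and "open" are said of these compounds alone.

The measured compounds:
Compound 1, `Cc1ccc(C(=O)NCN2CCC(c3cccc[n+]3[O-])CC2)cc1C`, gives 38 nM in a functional assay on HEK293 cells for agonist activity at D(4) dopamine receptor (Homo sapiens), read by FLIPR; a higher number here means that more compound is needed for the effect, a lower number that less compound is needed.
Compound 2, `C=Cc1cccc(C(=O)NCN2CCC(c3cccc[n+]3[O-])CC2)c1`, gives 68 nM in this assay.
Compound 3, `Cc1cccc(C(=O)NCN2CCC(c3cccc[n+]3[O-])CC2)c1`, gives 89 nM in this assay.

Compound 3 stands highest of the three numbers; its nearest neighbour is compound 2, with a 1.3-fold higher number from compound 2 to compound 3 (0.12 log units; within the scatter), and its furthest is compound 1, with a 2.3-fold higher number from compound 1 to compound 3 (0.37 log units; beyond the scatter). Compound 4, `O=C(NCN1CCC(c2cccc[n+]2[O-])CC1)c1ccc(F)c(Cl)c1`, has not yet been measured. The change from compound 3 to compound 4 is 3-chloro-4-fluorophenyl in place of 3-methylphenyl on a carbonyl carbon. Three earlier steps bear on it. The whole aryl group on the carbonyl carbon was exchanged once before, giving a 1.8-fold higher number from compound 1 to compound 2 (0.25 log units; within the scatter); a single methyl on an aromatic carbon was removed in a 2.3-fold higher number from compound 1 to compound 3 (0.37 log units; beyond the scatter), and a vinyl was swapped for a methyl in a 1.3-fold higher number from compound 2 to compound 3 (0.12 log units; within the scatter). All three steps are small, and none of them introduces a halogen, so the data give no direction for the present change. Compound 4 is therefore expected to show a 1.4-fold lower number from compound 3 to compound 4 (0.14 log units; within the scatter), a step within the scatter. The estimate for compound 4 is 65 nM, with a range from 22 nM to 190 nM.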

Compound 4, half-maximal effective concentration: 63 nM
Estimate against measurement, compound 4: 1.0-fold (0.01 log units) above, within the range that was stated.
By their numbers in this assay, from the lowest: compounds 1, 4, 2 and 3 (each within the scatter of the next, the first and the last beyond it).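

Compound 4 shows that the place on the carbonyl carbon accepts an aryl group carrying halogens. In this assay, the 3-chloro-4-fluorophenyl group cannot be told apart from the 3-methylphenyl group (a 1.4-fold lower number from compound 3 to compound 4 (0.15 log units; within the scatter)) or from the 3-vinylphenyl group (a 1.1-fold lower number from compound 2 to compound 4 (0.03 log units; within the scatter)), nor from the 3,4-dimethylphenyl group (a 1.7-fold higher number from compound 1 to compound 4 (0.22 log units; within the scatter)), so compound 4 lies within the scatter of all three earlier compounds, even though compound 1 and compound 3 lie beyond the scatter of each other. No measurement shown here accounts for this near-equality of halogen and carbon substituents on the ring.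

The compounds shown leave open what chlorine and fluorine each contribute, since a 3-chlorophenyl group and a 4-fluorophenyl group do not appear among them, and the two halogens enter together in a single change. They also leave open whether the same tolerance in this assay would hold for an aryl group bearing an amine or a carboxylic acid, or for a longer chain in place of the aryl group on the carbonyl carbon.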